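Aryl-to-carboxyethyl swap on the shared core

This account rests on a few compounds, and the source may have more. Where it says the series, first, only, none or still open, it means among the compounds named here.

Measured compounds:
compound 1 `CCCCCCCCc1ccc(OCC(=O)Cn2nnc(-c3cccc(Cl)c3)n2)cc1`: 24 nM
compound 2 `CCCCCCCCc1ccc(OCC(=O)Cn2nnc(-c3ccccn3)n2)cc1`: 18 nM
compound 3 `CCCCCCCCc1ccc(OCC(=O)Cn2nnc(-c3cccs3)n2)cc1`: 32 nM

In an assay on microsomes from brain for inhibition of Fatty-acid amide hydrolase 1 (Rattus norvegicus), read by fluorescence and HPLC, with a stated time of 60 min (a lower number here means a stronger inhibitor, a higher number a weaker inhibitor), compound 3 gives 32 nM, the highest of the three numbers, yet its gaps to compound 1 and to compound 2 are within the scatter, so no order among the three is claimed. Compound 4 `CCCCCCCCc1ccc(OCC(=O)Cn2nnc(CCC(=O)O)n2)cc1` differs from compound 3 by 2-carboxyethyl in place of thiophen-2-yl on an aromatic carbon. The steps that touch this aromatic carbon, a 1.3-fold higher number from compound 1 to compound 3 (0.12 log units; within the scatter) and a 1.8-fold higher number from compound 2 to compound 3 (0.25 log units; within the scatter), each exchanged one ring for another and stayed within the scatter. Within the data shown here, no measured step replaces a ring at this position with a group that has no ring, so the present change is untested. For compound 4 a weaker number is nevertheless expected, a 4.7-fold higher number from compound 3 to compound 4 (0.67 log units; beyond the scatter). The estimate for compound 4 is 150 nM, with a range from 30 nM to 800 nM.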

Compound 4, half-maximal inhibitory concentration: 30 nM
For compound 4 the middle estimate is 5.0-fold (0.70 log units) above the measured one; measured number inside the range.
By their numbers in this assay, from the lowest: compounds 2, 1, 4 and 3 (each within the scatter of the next).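

In this assay, a ring on this aromatic carbon proves dispensable within these four compounds: 2-carboxyethyl, which has no ring, gives a 1.1-fold lower number from compound 3 to compound 4 (0.03 log units; within the scatter), a 1.7-fold higher number from compound 2 to compound 4 (0.22 log units; within the scatter) and a 1.3-fold higher number from compound 1 to compound 4 (0.10 log units; within the scatter). The tolerated range at this position therefore extends from rings to this open chain carrying a carboxylic acid. The compounds shown leave open whether an amine, a methyl ester or a longer chain ending in a carboxylic acid would also stay within the scatter. No available evidence accounts for this result.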